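Moving a Chlorine on the Dichlorophenyl Group

The compounds below may be only part of what the source reports. "The series", "measured", "known", "first", "only" and "open" are said of these compounds alone.

Compound 1 `C#Cc1cccc(Nc2ncnc3cc(NC(=O)/C=C/c4ccccc4)sc23)c1`: 700 nM
Compound 2 `O=C(/C=C/c1ccccc1)Nc1cc2ncnc(Nc3cc(Cl)cc(Cl)c3)c2s1`: 220 nM

For the measured compounds named here, in a functional assay on PC-3 cells (Homo sapiens) for antiproliferative activity, read by MTT assay, with a stated time of 48 h (on this read-out lower numbers stand for stronger inhibition and higher numbers for weaker inhibition), compound 2 gives 220 nM, the lower of the two numbers so far, and compound 1 gives 700 nM. The next molecule is compound 3 `O=C(/C=C/c1ccccc1)Nc1cc2ncnc(Nc3ccc(Cl)c(Cl)c3)c2s1`. It has the same atoms as compound 2, joined differently: 3,4-dichlorophenyl in place of 3,5-dichlorophenyl on a nitrogen on an aromatic ring. In words, 3,4-dichlorophenyl stands in place of 3,5-dichlorophenyl on a nitrogen on an aromatic ring.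

Going by the values given here, only one measured step bears on this change: a 3.2-fold lower number from compound 1 to compound 2 (0.50 log units; beyond the scatter). That modest step put 3,5-dichlorophenyl in place of 3-ethynylphenyl on the same nitrogen. It swapped one group for a different one, whereas compound 3 keeps both chlorines on its ring. Among the compounds with values here, no pair of dichlorophenyl isomers has been measured, so the direction cannot be read from the data. A smaller step than that one is therefore expected, probably within the scatter, and the estimate leans slightly towards a weaker result. The expected step is a 1.2-fold higher number from compound 2 to compound 3 (0.07 log units; within the scatter). For compound 3 the estimated value is 260 nM, with an expected range of 100 nM to 650 nM.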

Compound 3, half-maximal inhibitory concentration: 260 nM
Estimate against measurement, compound 3: no gap at the digits printed; measured number inside the range.
By their numbers in this assay, from the lowest: compounds 2 and 3 (each within the scatter of the next); then compound 1.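

In this assay, moving one chlorine gives a 1.2-fold higher number from compound 2 to compound 3 (0.07 log units; within the scatter), so at this nitrogen the 3,5-dichlorophenyl and 3,4-dichlorophenyl groups cannot be told apart on this read-out, even though the swap changes how the ring's atoms are joined. The comparison with the ethynyl compound now has a second example: a 2.7-fold lower number from compound 1 to compound 3 (0.43 log units; beyond the scatter), so both dichlorophenyl compounds give lower numbers than compound 1, and among these three compounds none goes against that pattern. Nothing measured here explains why the chlorine arrangement makes no clear difference or why either dichlorophenyl group differs from 3-ethynylphenyl.

These compounds leave open whether both chlorines are needed at all, since a ring with a single chlorine, or with a methoxy group or an amine in place of the chlorines, could give a quite different number. From the compounds shown here alone, the amide and its phenyl-bearing chain are the same in all three compounds, so it also remains open how a carboxylic acid or a longer chain in that part would compare.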